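Cytotoxicity of pyrazoline amides: a bromo-to-methoxy swap

This account rests on a few compounds, and the source may have more. Where it says the series, first, only, none or still open, it means among the compounds named here.

Measured so far:
- Compound 1 `Cn1cc(C2CC(c3ccc(Br)cc3)=NN2C(=O)c2cccnc2)c2cc(Br)ccc21`: in an ADME assay on HEK-293T cells (Homo sapiens) for cytotoxicity, read by MTT assay, with a stated time of 48 h (on this read-out lower numbers stand for higher toxicity in this test and higher numbers for lower toxicity in this test), compound 1 gives > 300000 nM, which is a limit of the measurement rather than a number.
- Compound 2 `COc1ccc(C2=NN(C(=O)c3cccnc3)C(c3cn(C)c4ccc(Br)cc34)C2)cc1`: in this assay compound 2 gives > 300000 nM, again a limit.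
- Compound 3 `COc1ccc2c(c1)c(C1CC(c3ccc(Br)cc3)=NN1C(=O)c1ccc(OC)nc1)cn2C`: in this assay compound 3 gives > 300000 nM, also a limit.

All three readings therefore sit at the same limit, as summarised by the limit of > 300000 nM in this assay, at which 3 of the 3 values shown sit. None of the three compounds harmed the cells enough within the tested range to yield a numerical concentration.

Compound 1 and compound 2 differ in one place only: methoxy in place of bromo on an aromatic carbon. Both readings are limits. The resulting step that the two limits leave unreadable from compound 1 to compound 2 cannot be sized; all that can be said is that the change did not bring the toxicity into the measurable range.

Compound 4 `COc1ccc(C2=NN(C(=O)c3ccc(OC)nc3)C(c3cn(C)c4ccc(OC)cc34)C2)cc1` is not yet measured. It is made from compound 3 by the same change, (methoxy in place of bromo on an aromatic carbon), at the same kind of position. The difference between the core of compound 3 and that of compound 1 is not broken down here.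

For compound 4 in this assay the expectation rests on compound 3 giving > 300000 nM and on the pair compound 1 to compound 2 staying at the limit: the step that the limit leaves unreadable from compound 3 to compound 4 is expected to be small or unreadable. Compound 4 is accordingly estimated at 400000 nM, most likely again reported as a limit, with a plausible range from 200000 nM to 1000000 nM.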

Compound 4, half-maximal cytotoxic concentration: > 300000 nM
Compound 4: a limit, no number; the forecaster's own chance of this, stated with the estimate: 85%; the middle value is on the limit's open side.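

Compound 3 and compound 4 both rest on a limit of the measurement rather than a number, so no size can be read for the step between them. All four compounds now share one reading: the limit of > 300000 nM in this assay, at which 4 of the 4 values shown sit. The compounds shown leave open how far each lies beyond that limit, and whether any single change would bring toxicity in this assay into the measurable range.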